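The source may hold more compounds than are shown below. What is called first, only, known or untested is meant among the compounds shown, and "the series" means these compounds.

Working notes on the series. Among the measured compounds shown here, in a functional assay on HCT-116 cells (Homo sapiens) for cytotoxicity, read by MTT assay, with a stated time of 48 h (on this read-out higher numbers stand for weaker inhibition and lower numbers for stronger inhibition), compound 1 (`O=C(/C=C\Nc1ccccc1)c1ccc2c(c1)CCCC2`) gives 41.6 ug/mL, the higher of the two numbers so far. Compound 2 (`O=C(/C=C\Nc1ccc(Cl)cc1)c1ccc2c(c1)CCCC2`) gives 7.9 ug/mL. For the measured compounds named here, the one measured step, chloro in place of hydrogen on an aromatic carbon, is a 5.3-fold lower number from compound 1 to compound 2 (0.72 log units; beyond the scatter).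

Compound 3 (`Cc1ccc(N/C=C\C(=O)c2ccc3c(c2)CCCC3)cc1`) has not been measured. It departs from compound 1 by methyl in place of hydrogen on an aromatic carbon, with methyl in place of hydrogen on an aromatic carbon, para to a large group. Going by the values given here, no measured step involves methyl, so the chloro step of a 5.3-fold lower number from compound 1 to compound 2 (0.72 log units; beyond the scatter) is the only guide, and a weak one. A smaller step in the same direction is expected in this assay, and it may stay within the scatter. The expected step is a 1.9-fold lower number from compound 1 to compound 3 (0.28 log units; within the scatter). For compound 3 the estimate is 22 ug/mL, with an expected range of 9 ug/mL to 50 ug/mL.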

Compound 3, half-maximal inhibitory concentration: 42.1 ug/mL
For compound 3 the middle estimate is 1.9-fold (0.28 log units) below the measured one; low and high end bracket the measured number.
By their numbers in this assay, from the lowest: compound 2; then compounds 1 and 3 (each within the scatter of the next).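

At the place para to a large group, methyl does not carry the chloro result over: in this assay the change reads as a 1.0-fold higher number from compound 1 to compound 3 (0.01 log units; within the scatter) and leaves methyl and hydrogen indistinguishable on this read-out. Methyl in place of chloro at the same carbon gives a 5.3-fold higher number from compound 2 to compound 3 (0.73 log units; beyond the scatter) and so sets compound 2 apart from compound 3, which shows that the lower number seen so far goes with chloro alone and not with any group placed here. Nothing available on these compounds accounts for the difference between chloro and methyl.

From the compounds shown here alone, whether fluoro, bromo, methoxy or an amine at this place would track compound 2 or compound 3 remains open. Also open, going by these compounds, is whether the chloro step holds at any other carbon of the same ring, since only this one place is covered.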